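Ester chain exchange at the acyl end of compound 3

This account rests on a few compounds, and the source may have more. Where it says the series, first, only, none or still open, it means among the compounds named here.

Measured compounds:
Compound 1 `CC(c1ccc2oc(-c3ccccc3)cc2c1)N(O)C(=O)c1ccccc1`: in an assay on RBL cells for inhibition of Polyunsaturated fatty acid 5-lipoxygenase (Rattus norvegicus) (on this read-out higher numbers stand for weaker inhibition and lower numbers for stronger inhibition), compound 1 gives 4830 nM.
Compound 2 `CC(c1ccc2oc(-c3ccccc3)cc2c1)N(O)C(=O)c1cccs1`: in this assay compound 2 gives 250 nM.
Compound 3 `CC(=O)OCC(=O)N(O)C(C)c1ccc2oc(-c3ccccc3)cc2c1`: in this assay compound 3 gives 160 nM.

Compound 3 holds the lowest of the three numbers, but a 1.6-fold lower number from compound 2 to compound 3 (0.19 log units; within the scatter) lies within the scatter, so compound 2 and compound 3 cannot be set apart; only a 30-fold lower number from compound 1 to compound 3 (1.48 log units; beyond the scatter) is clearly large. Compound 4 `COC(=O)CCCC(=O)N(O)C(C)c1ccc2oc(-c3ccccc3)cc2c1` differs from compound 3 in one place: 2-(methoxycarbonyl)ethyl in place of acetoxy on a saturated chain carbon bound to a carbonyl carbon. The two large measured steps, a 19-fold lower number from compound 1 to compound 2 (1.29 log units; beyond the scatter) and a 30-fold lower number from compound 1 to compound 3 (1.48 log units; beyond the scatter), both removed a phenyl from the carbonyl carbon, and compound 4 has no such phenyl either; neither step exchanges one ester-bearing chain for another. Among the compounds with values here, the only measured step between two non-phenyl acyl groups stayed within the scatter. Compound 4 is therefore expected to show no step beyond the scatter in this assay, and the step from compound 3 is estimated as a 1.3-fold higher number from compound 3 to compound 4 (0.10 log units; within the scatter). Compound 4 is estimated at 200 nM, with a range from 70 nM to 600 nM.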

Compound 4, half-maximal inhibitory concentration: 60 nM
The estimate for compound 4 lay 3.3-fold (0.52 log units) above the measured number; measured number below the stated range.
By their numbers in this assay, from the lowest: compound 4; then compounds 3 and 2 (each within the scatter of the next); then compound 1.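

Even among acyl groups with no phenyl on the carbonyl carbon, this position still responds to the group it carries: in this assay, 2-(methoxycarbonyl)ethyl in place of acetoxy gives a 2.7-fold lower number from compound 3 to compound 4 (0.43 log units; beyond the scatter), the first step beyond the scatter between two ester-bearing chains. The same chain also separates from the thiophen-2-yl group, with a 4.2-fold lower number from compound 2 to compound 4 (0.62 log units; beyond the scatter), although compound 2 and compound 3 could not be told apart, and against the phenyl group it gives an 81-fold lower number from compound 1 to compound 4 (1.91 log units; beyond the scatter), so compound 4 is the strongest inhibitor of the four. No available evidence explains this gain. The compounds shown do not separate the larger heavy-atom count of the entering group from the reversed direction of its ester. As far as these compounds go, whether a longer chain or a carboxylic acid in place of the methyl ester would hold this number also remains open.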